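Bromothiophene Extension on a Thiophene-Bearing Amine Core

The compounds below may be only part of what the source reports. "The series", "measured", "known", "first", "only" and "open" are said of these compounds alone.

Three compounds share the core of compound 1 `CCc1ccc(CN[C@@H]2C[C@H]3C[C@@H]([C@H]2C)C3(C)C)s1` and have been run in an ADME assay on MDCK cells (Canis lupus familiaris) for cytotoxicity, read by microscopy, with a stated time of 48 h; on this read-out higher numbers stand for lower toxicity in this test and lower numbers for higher toxicity in this test. In this assay compound 1 gives 1560 nM, the lowest of the three numbers. Compound 3 `C[C@H]1[C@H](NCc2cc(Br)cs2)C[C@H]2C[C@@H]1C2(C)C` gives 6250 nM in this assay, a higher number than compound 1, beyond the scatter. Compound 2 `C=Cc1ccsc1CN[C@@H]1C[C@H]2C[C@@H]([C@H]1C)C2(C)C` gives 50000 nM in this assay, a still higher number than compound 1, also beyond the scatter. No pair of these compounds differs in one place only, so no single step between measured compounds is available.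

Compound 4 `C[C@H]1[C@H](NCc2ccc(-c3ccc(Br)s3)s2)C[C@H]2C[C@@H]1C2(C)C` has not yet been measured in this assay. It differs from compound 1 by the change (5-bromothiophen-2-yl in place of ethyl on an aromatic carbon), on an aromatic carbon of a five-membered aromatic ring with 1 sulfur. Within the data shown here, no measured step shows what this change does in this assay. The account therefore rests on compound 1 alone, and the author expects for compound 4 a step of a 1.3-fold higher number from compound 1 to compound 4 (0.11 log units; within the scatter) that stays within or just beyond the scatter, with no firm direction. The author estimates that compound 4 will give 2000 nM in this assay, within a range from 400 nM to 10000 nM.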

Compound 4, minimum cytotoxic concentration: 780 nM
The estimate for compound 4 lay 2.6-fold (0.41 log units) above the measured number; the range from low to high includes it.
By their numbers in this assay, from the lowest: compounds 4 and 1 (each within the scatter of the next); then compound 3; then compound 2.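

The step of a 2.0-fold lower number from compound 1 to compound 4 (0.30 log units; within the scatter) in this assay comes with 5-bromothiophen-2-yl in place of ethyl, on an aromatic carbon next to the ring sulfur. Among these compounds, this is the first single change, and it shows that this position can carry a group of 6 heavy atoms with its own five-membered aromatic ring, instead of 2 carbons, while the read-out stays within the scatter. Nothing available here explains this result.

The compounds shown leave open whether the bromine matters, since no thiophen-2-yl without it stands beside compound 4. They also leave open whether this position would tolerate a different kind of group, such as a carboxylic acid, an amine or a longer alkyl chain, in the same way.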